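The source may report more compounds than this note shows. Statements on the series, on what has been measured and on what is new or still open speak of the compounds shown alone.

Compound 1, with the structure `COc1cc(OC)n2cc(-c3ccc(N)cc3)nc2n1`, carries a free amine on its aromatic ring. In a functional assay on LoVo cells (Homo sapiens) for antiproliferative activity, read by MTT assay, with a stated time of 72 h (a higher number here means a weaker inhibitor of growth, a lower number a stronger inhibitor of growth), compound 1 gives > 100000 nM, which is a limit of the assay rather than a number. Compound 2, `COc1cc(OC)n2cc(-c3ccc(NCc4ccccc4)cc3)nc2n1`, differs from compound 1 by benzyl in place of hydrogen on a nitrogen on an aromatic ring. In this assay compound 2 also gives > 100000 nM, again a limit and not a number. Hence the step that the two limits leave unreadable from compound 1 to compound 2 cannot be read, since (the limit of > 100000 nM in this assay, at which 2 of the 3 values shown sit).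

Compound 3, `Cc1ccn2cc(-c3ccc(NCc4ccccc4)cc3)nc2c1`, rests on a different core; the difference between the two cores is not broken down here. In this assay compound 3 has "not determined" (no result reported). Compound 4, `Cc1ccn2cc(-c3ccc(N(Cc4ccccc4)Cc4ccccc4)cc3)nc2c1`, differs from compound 3 by benzyl in place of hydrogen on a nitrogen on an aromatic ring. This is the same kind of change as that from compound 1 to compound 2, but not the same: in compound 3 the nitrogen's other neighbours are an aromatic carbon and a saturated chain carbon, whereas in compound 1 the nitrogen's only other neighbour is an aromatic carbon.

For compound 4 the expectation in this assay can rest only on the fact that compound 1 gives > 100000 nM and compound 2 gives > 100000 nM, both limits, and on compound 3 having no value at all. Compound 4 is therefore expected to give about 80000 nM, within a range from 10000 nM to 200000 nM, most likely as another limit.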

Compound 4, concentration for 50% growth inhibition: 5700 nM
For compound 4 the middle estimate is 14-fold (1.15 log units) above the measured one; measured number outside the range, below it.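

In this assay compound 4 gives 5700 nM, while compound 3 offers no number to set against it, so no new step can be read from this pair. The compounds shown leave open how much of the growth inhibition by compound 4 goes with its added benzyl and how much goes with its core, which differs from that of compound 1 and compound 2.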